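Cytotoxicity notes: halogen removal on the fused lactone ring

This account rests on a few compounds, and the source may have more. Where it says the series, first, only, none or still open, it means among the compounds named here.

Measured compounds:
Compound 1: `NCCC(=O)N1Cc2ccccc2-c2nnn(-c3cc4cc(Br)ccc4oc3=O)c2-c2ccccc21` — 100000 nM
Compound 2: `NCCC(=O)N1Cc2ccccc2-c2nnn(-c3cc4cc(Cl)cc(Cl)c4oc3=O)c2-c2ccccc21` — 185000 nM

Among the measured compounds shown here, the two measured members share one core and differ only in the substitution on the fused ring that carries the lactone. In a toxicity assay on MRC5 cells (Homo sapiens) for cytotoxicity, read by MTT assay, with a stated time of 24 h (a higher number here means a weaker inhibitor, a lower number a stronger inhibitor), compound 1 gives 100000 nM. In the same assay compound 2 gives 185000 nM; the two numbers fall within the usual scatter of each other, so the data show no separation between them. Both values sit at very weak inhibition.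

Compound 3, `NCCC(=O)N1Cc2ccccc2-c2nnn(-c3cc4ccccc4oc3=O)c2-c2ccccc21`, has not yet been tested in this assay. Relative to compound 1 it carries the following change: hydrogen in place of bromo on an aromatic carbon, meta to a fused ring and para to a fused ring. For the measured compounds named here, no step between measured compounds probes this position, so the expectation rests on the two measured values only, which both lie at the weak end. For compound 3 a step of no more than the scatter is expected, in either direction, written as a 1.1-fold higher number from compound 1 to compound 3 (0.04 log units; within the scatter). The estimate for compound 3 in this assay is 110000 nM, with a range from 50000 nM to 250000 nM.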

Compound 3, half-maximal inhibitory concentration: 110000 nM
For compound 3 middle estimate and measured number coincide at the digits printed; measured number inside the range.
By their numbers in this assay, from the lowest: compounds 1, 3 and 2 (each within the scatter of the next).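

In this assay the series now has a single step that isolates one position: hydrogen in place of bromo on an aromatic carbon, meta to a fused ring and para to a fused ring, gives a 1.1-fold higher number from compound 1 to compound 3 (0.04 log units; within the scatter) and so shows no separation between the two compounds. The earlier pair differed in more than one place and could not isolate this position, whereas this step shows that the bromo is not needed to keep the number at the weak end of this read-out. No accompanying measurement bears on this result, so the data offer no explanation for the size of the step.

Among the compounds shown here, whether another group at this position, such as an amine, a carboxylic acid or a methoxy group, would separate from compound 1 remains open, as the only change read here is hydrogen in place of bromo. Also open is whether the same change would stay within the scatter on a core with a different chain, such as a longer amino-bearing chain, since all the compounds shown share the same chain.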